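The source may hold more compounds than are shown below. What is called first, only, known or untested is meant among the compounds shown, and "the series" means these compounds.

Measured compounds in an assay on isolated protein for inhibition of histone deacetylase 4 (Homo sapiens), with a stated time of 1 h; a higher number here means a weaker inhibitor, a lower number a stronger inhibitor:
- compound 1 `O=C(COc1ccc2cc(/C=C3/SC(=O)NC3=O)ccc2c1)Nc1ccc(F)cc1F` gives 3900 nM
- compound 2 `O=C(COc1ccc2cc(/C=C3/SC(=O)NC3=O)ccc2c1)Nc1ccc(Cl)c(Cl)c1` gives 5500 nM
- compound 3 `Cc1cccc(NC(=O)COc2ccc3cc(/C=C4/SC(=O)NC4=O)ccc3c2)n1` gives 1100 nM

Compound 3 holds the lowest number of the three. Its two steps from the carbocyclic amides both lie beyond the scatter: a 3.5-fold lower number from compound 1 to compound 3 (0.55 log units; beyond the scatter) and a 5.0-fold lower number from compound 2 to compound 3 (0.70 log units; beyond the scatter). Between the two carbocyclic amides themselves the step is small: a 1.4-fold higher number from compound 1 to compound 2 (0.15 log units; within the scatter), within the scatter, so these two cannot be ordered.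

Compound 4 `O=C(COc1ccc2cc(/C=C3/SC(=O)NC3=O)ccc2c1)Nc1cccc(Cl)c1` is the next member. The change from compound 3 is 3-chlorophenyl in place of 6-methylpyridin-2-yl on an amide-type nitrogen. This returns to a halogenated carbocyclic ring of the kind seen in compound 1 and compound 2, so the two steps that bear on it are the ones that led to compound 3, read in reverse. Both were modest and in the same direction, which gives a consistent expectation: the number in this assay for compound 4 is expected to rise, roughly undoing the gain seen at compound 3, with a step of about a 3.2-fold higher number from compound 3 to compound 4 (0.50 log units; beyond the scatter). The estimate for compound 4 is 3500 nM, with a range of 1500 nM to 8000 nM.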

Compound 4, half-maximal inhibitory concentration: 3800 nM
The estimate for compound 4 lay 1.1-fold (0.04 log units) below the measured number, and the stated range covers the measured number.
By their numbers in this assay, from the lowest: compound 3; then compounds 4, 1 and 2 (each within the scatter of the next).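

Placing 3-chlorophenyl in place of 6-methylpyridin-2-yl on the amide-type nitrogen gives a 3.5-fold higher number from compound 3 to compound 4 (0.54 log units; beyond the scatter), so in this assay compound 3 now stands apart from three carbocyclic amides rather than two. Among these amides the halogen pattern gives no readable difference: a 1.4-fold lower number from compound 2 to compound 4 (0.16 log units; within the scatter), with hydrogen in place of chloro on an aromatic carbon, and a 1.0-fold lower number from compound 1 to compound 4 (0.01 log units; within the scatter), both lie within the scatter. No measurement at hand accounts for the gap to compound 3.

Still open, on these data alone, is whether the lower number of compound 3 goes with the ring nitrogen or with the methyl of 6-methylpyridin-2-yl, which a plain pyridin-2-yl would separate. Also open, as far as these compounds go, is how an amine or a carboxylic acid on this ring would read.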